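The compounds below may be only part of what the source reports. "The series", "measured", "known", "first", "only" and "open" are said of these compounds alone.

Measured in a physicochemical assay for solubility, in phosphate buffer, at pH 7.4; a higher number here means a more soluble compound, a lower number a less soluble compound:
- Compound 1 `COc1cc(F)ccc1-c1ccnc2[nH]c(C3CCN(CC(=O)N(C)C)CC3)cc12` gives 38000 nM
- Compound 2 `CC(C)n1nc(-c2ccnc3[nH]c(C4CCN(CC(=O)N(C)C)CC4)cc23)ccc1=O` gives 11000 nM
- Compound 3 `CC(C)Cn1cc(-c2ccnc3[nH]c(C4CCN(CC(=O)N(C)C)CC4)cc23)ccc1=O` gives 390000 nM

Of these three, compound 3 stands highest. Compound 4 `CC(C)n1cc(-c2ccnc3[nH]c(C4CCN(CC(=O)N(C)C)CC4)cc23)ccc1=O` differs from it by one small change: isopropyl in place of isobutyl on an aromatic nitrogen. For the measured compounds named here, no measured step changes this group alone. Going by the values given here, the only step available, a 3.5-fold lower number from compound 1 to compound 2 (0.54 log units; beyond the scatter), swaps one aromatic ring for another and so bears only loosely, though it shows that this assay can move beyond the scatter. Compound 2 also carries isopropyl and gives 11000 nM, but its ring differs too. A small downward step is therefore expected, possibly none beyond the scatter. The expected step is a 2.0-fold lower number from compound 3 to compound 4 (0.29 log units; within the scatter). The estimate for compound 4 is 200000 nM, with an expected range from 60000 nM to 500000 nM.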

Compound 4, solubility: 110000 nM
Beside the measured number, compound 4's estimate is 1.8-fold (0.26 log units) above it; the range from low to high includes it.
By their numbers in this assay, from the lowest: compound 2; then compound 1; then compound 4; then compound 3.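

Isopropyl in place of isobutyl on an aromatic nitrogen gives a 3.5-fold lower number from compound 3 to compound 4 (0.55 log units; beyond the scatter) in this assay and so shows that this small change alone can move the number beyond the scatter. Changing the aromatic group on the shared core gives a 10-fold higher number from compound 2 to compound 4 (1.00 log units; beyond the scatter) and a 2.9-fold higher number from compound 1 to compound 4 (0.46 log units; beyond the scatter) in this assay as well. Nothing measured here explains these steps.

Two chains cannot show whether a methyl, a longer chain such as pentyl, or a chain ending in an amine on this nitrogen would raise or lower the number.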